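Swapping the Aryl Group on a Piperazine Sulfonamide

This account rests on a few compounds, and the source may have more. Where it says the series, first, only, none or still open, it means among the compounds named here.

Measured so far:
Compound 1, `COC(=O)c1ccc(C2SCC(=O)N2c2ccc(N3CCNCC3)cn2)c(OC)c1`: 15200 nM in a functional assay on K562 cells (Homo sapiens) for antiproliferative activity, read by MTT assay and trypan blue exclusion, with a stated time of 72 h; on this read-out lower numbers stand for stronger inhibition and higher numbers for weaker inhibition
Compound 2, `COC(=O)c1ccc(C2SCC(=O)N2c2ccc(N3CCN(S(=O)(=O)c4c(C)cc(C)cc4C)CC3)cn2)c(OC)c1`: 53500 nM in this assay

Among these two numbers compound 2 stands highest, meaning the weakest inhibition seen so far; its only neighbour is compound 1, and the step between them, a 3.5-fold higher number from compound 1 to compound 2 (0.55 log units; beyond the scatter), is modest but beyond the scatter.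

Compound 3, `COC(=O)c1ccc(C2SCC(=O)N2c2ccc(N3CCN(S(=O)(=O)c4ccc([N+](=O)[O-])cc4)CC3)cn2)c(OC)c1`, keeps everything in compound 2 except the aryl group attached to the sulfonyl: 4-nitrophenyl in place of 2,4,6-trimethylphenyl on a sulfonyl sulfur. The ring stays six-membered and aromatic, but three methyl groups give way to a single nitro group.

For the measured compounds named here, no measured pair compares two different aryl groups on this sulfonyl sulfur. Going by the values given here, the single step known, a 3.5-fold higher number from compound 1 to compound 2 (0.55 log units; beyond the scatter), describes attaching the whole sulfonyl unit to the ring nitrogen, not exchanging one aryl for another, so it offers no direction for this change. The expectation is therefore a step of about a 1.1-fold lower number from compound 2 to compound 3 (0.03 log units; within the scatter), that is, nothing beyond the scatter, in this assay.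

Compound 3 is estimated at 50000 nM, with a range from 18000 nM to 140000 nM.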

Compound 3, half-maximal inhibitory concentration: 65200 nM
Compound 3: middle estimate off by 1.3-fold (0.12 log units), on the low side; the measured number falls inside the stated range.
By their numbers in this assay, from the lowest: compound 1; then compounds 2 and 3 (each within the scatter of the next).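

In this assay, 4-nitrophenyl in place of 2,4,6-trimethylphenyl on a sulfonyl sulfur gives a 1.2-fold higher number from compound 2 to compound 3 (0.09 log units; within the scatter), so these two aryl groups cannot be told apart on this read-out, even though three methyl groups in one stand against a single nitro group in the other. Compound 1, with hydrogen on the ring nitrogen, now has two sulfonamide partners, and the second step, a 4.3-fold higher number from compound 1 to compound 3 (0.63 log units; beyond the scatter), points the same way as the first, a 3.5-fold higher number from compound 1 to compound 2 (0.55 log units; beyond the scatter), so among these three compounds the higher number goes with the arylsulfonyl unit as a whole, whichever of the two aryl groups it carries. The data shown hold no separate measurement that could explain these results.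

As far as these compounds go, whether the aryl group matters at all on this sulfonyl sulfur remains open, since a phenyl ring carrying an amine or a carboxylic acid, or a small methyl group in place of the aryl ring, could still read differently. From the compounds shown here alone, it is also open whether a carbonyl-linked group such as acetyl on the ring nitrogen would go the same way as the sulfonyl unit.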